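The compounds below may be only part of what the source reports. "The series", "measured", "known", "first", "only" and "open" are said of these compounds alone.

Working notes on a small set of acylthiourea compounds built on a shared core. Three of them have been run in an ADME assay on Huh-7 cells (Homo sapiens) for cytotoxicity; a higher number here means that more compound is tolerated, a lower number that less compound is tolerated. Compound 1 `O=C(NC(=S)N1CCc2c(OCc3ccccc3)cccc21)c1ccccc1` gives > 50000 nM, which is a limit of the assay and not a number. Compound 2 `O=C(NC(=S)N1CCc2ccc(OCc3ccccc3)cc21)c1ccccc1` gives 43800 nM. Compound 3 `N#Cc1ccc(C(=O)NC(=S)N2CCc3c(OCCCCCOc4ccc(Cl)cc4)cccc32)cc1` gives > 50000 nM, again a limit rather than a measured number. Within the data shown here, compound 3 therefore stands at the limit of > 50000 nM in this assay, at which 2 of the 3 values shown sit, and no step between two measured compounds that differ in one place is available to size the effect of any single change in this assay.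

Compound 4 `CN(C)c1ccc(C(=O)NC(=S)N2CCc3c(OCCCCCOc4ccc(Cl)cc4)cccc32)cc1` is the next compound to be measured in this assay. It differs from compound 3 in one place: dimethylamino in place of cyano on an aromatic carbon. With compound 3 sitting at a limit, there is no measured anchor for the direction of this change. The expectation is no movement beyond the scatter, and the step from compound 3 to compound 4 is estimated as a number no higher from compound 3 to compound 4 (the limit leaves the size open). Compound 4 is accordingly expected to give about 50000 nM in this assay, within a range of 25000 nM to 100000 nM, and most likely to return another limit rather than a number.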

Compound 4, half-maximal cytotoxic concentration: > 50000 nM
Compound 4: only a limit was reported; the forecaster's own chance of this, stated with the estimate: 65%; the middle value sits exactly at the limit.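

In this assay, compound 3 and compound 4 both return a limit of the assay and not a number, so no step can be read for dimethylamino in place of cyano. The position in the series stands as: the limit of > 50000 nM in this assay, at which 3 of the 4 values shown sit.

The compounds shown leave open the size and direction of this change, and of any other single change on the shared core, in this assay.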